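The compounds below may be only part of what the source reports. "The series", "measured", "known", "first", "only" and "open" are said of these compounds alone.

Measured compounds:
- compound 1 `Oc1ccc(CNc2cc(C(F)(F)F)cc3[nH]ncc23)cc1` — 91%
- compound 2 `FC(F)(F)c1cc(NC[C@H]2CCCN2)c2cn[nH]c2c1` — 84%
- compound 3 `O=[N+]([O-])c1cc(OCc2ccccc2)ccc1CNc1cc(C(F)(F)F)cc2[nH]ncc12` — 55%

In an assay for inhibition of Tryptophan 2,3-dioxygenase (Homo sapiens), with stated times of 10 min and 60 min, tested at 100 uM (a higher number here means a stronger effect of the compound at the concentration tested, a lower number a weaker effect), compound 1 gives the highest of the three numbers shown. The nearest is compound 2, and the step of a number 7 percentage points lower from compound 1 to compound 2 (within the scatter) lies within the scatter, so the two cannot be ranked. Compound 3 sits furthest away, its number well beyond the scatter below that of compound 1.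

The next compound, compound 4 `Oc1ccc(CNc2cc(C(F)(F)F)cc3[nH]ncc23)c(Cl)c1`, differs from compound 1 by a single change: chloro in place of hydrogen on an aromatic carbon. Among the compounds with values here, none of the measured steps bears directly on this change. Within the data shown here, the only step, from compound 1 to compound 2, replaces the whole aromatic ring and gives no information on adding a chloro group to it; compound 3 changes more than one place and tells nothing either. Among the measured compounds shown here, with no bearing step, the expectation for this assay is a step of no size beyond the scatter, a number 3 percentage points lower from compound 1 to compound 4 (within the scatter). Compound 4 is therefore estimated to give 88%, within a range of 74% to 97%.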

Compound 4, a percentage reported as inhibition, at one concentration (the size of the read-out at that concentration, not a potency): 97%
Compound 4: the middle estimate sits 9 percentage points below what was measured; low and high end bracket the measured number.
By their numbers in this assay, from the lowest: compound 3; then compounds 2, 1 and 4 (each within the scatter of the next, the first and the last beyond it).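

In this assay, chloro in place of hydrogen on an aromatic carbon, ortho to a large group and meta to a hydroxy group, gives a number 6 percentage points higher from compound 1 to compound 4 (within the scatter) and so leaves the two compounds unranked. Unlike the step to compound 2, which replaces the whole 4-hydroxyphenyl group, this change keeps that ring and shows that this position takes a chloro group with no shift beyond the scatter. Nothing at hand bears on why the read-out holds at this position.

As far as these compounds go, whether a fluoro, methyl or methoxy group on this same carbon would also stay within the scatter of compound 1 remains open. From the compounds shown here alone, with a read-out at a single concentration, whether compound 1 and compound 4 would differ in effect at any other concentration also remains open.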